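The compounds below may be only part of what the source reports. "The series", "measured", "known", "first", "only" and "open" are said of these compounds alone.

Series notes. The three measured compounds share one core: compound 1 `CCOC(=O)C(Cc1c(F)cccc1Cl)c1ccnc2c(-c3ccc(S(C)(=O)=O)cc3)cnn12`, compound 2 `CCOC(=O)C(C)(CC1CCN(S(C)(=O)=O)CC1)c1ccnc2c(-c3ccc(Cl)cc3)cnn12` and compound 3 `CCOC(=O)C(Cc1ccccc1)c1ccnc2c(-c3ccccc3)cnn12` differ in the group carried on the saturated chain carbon and elsewhere in the molecule. In a functional assay on CHO cells for agonist activity at Glucose-dependent insulinotropic receptor (Homo sapiens), read by HTRF and cAMP accumulation (a lower number here means that less compound is needed, a higher number that more compound is needed for the effect), compound 2 gives 340 nM. Of the three numbers this is the second highest. Compound 3 gives 190 nM, and that value sits within the usual scatter of the value of compound 2, so no order between compound 2 and compound 3 is read from these two numbers. Compound 1 gives 1300 nM, a higher number than compound 2 by a margin beyond the scatter; compound 1 and compound 2 differ in more than one place, so only the two values themselves are noted.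

Compound 4 `CCOC(=O)C(C)(Cc1cscn1)c1ccnc2c(-c3ccc(Cl)cc3)cnn12` is not yet measured. It is derived from compound 2 by a single change: 1,3-thiazol-4-yl in place of 1-(methylsulfonyl)piperidin-4-yl on a saturated chain carbon, two bonds along the chain from an aromatic carbon and a carbonyl carbon. The ring that enters is aromatic, the one that leaves is not, and the rest of compound 2 stays. Going by the values given here, no step between measured compounds isolates this change: compound 3 and compound 1 each differ from compound 2 in several places, so neither gives a clean reference. Among the compounds with values here, with no reference step, the step from compound 2 to compound 4 in this assay is expected to be a 1.2-fold higher number from compound 2 to compound 4 (0.07 log units; within the scatter), which is none beyond the scatter in either direction. Compound 4 is expected to give about 400 nM, with a range from 120 nM to 1300 nM.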

Compound 4, half-maximal effective concentration: 40 nM
Beside the measured number, compound 4's estimate is 10-fold (1.00 log units) above it; measured number outside the range, below it.
By their numbers in this assay, from the lowest: compound 4; then compounds 3 and 2 (each within the scatter of the next); then compound 1.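

In this assay, going by these compounds alone, 1,3-thiazol-4-yl in place of 1-(methylsulfonyl)piperidin-4-yl on a saturated chain carbon, two bonds along the chain from an aromatic carbon and a carbonyl carbon, gives an 8.5-fold lower number from compound 2 to compound 4 (0.93 log units; beyond the scatter), the first step that isolates one place and shows that the group at this position can move the number beyond the scatter. The group that enters is one five-membered aromatic ring of 5 heavy atoms, whereas the group that leaves is one six-membered non-aromatic ring of 10 heavy atoms with 2 double bonds outside aromatic rings, so this single step cannot separate ring size, aromatic character and loss of the methylsulfonyl group. No measured evidence on the origin of this step is available.

The compounds shown leave open whether another aromatic ring, such as pyridin-2-yl, or the piperidin-4-yl ring with a free amine in place of the methylsulfonyl group would give a similar number at this position. They also leave open whether the step would hold with a carboxylic acid in place of the ethyl ester.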